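The compounds below may be only part of what the source reports. "The series", "measured", "known", "first", "only" and "open" are said of these compounds alone.

Of the compounds shown here, three on a shared core have so far been measured in a physicochemical assay for lipophilicity, in phosphate buffer, measured as octanol-water partition, at pH 6.8; a higher number here means a more lipophilic compound, a lower number a more polar compound. Compound 1 `CCN(CC)CCNc1c(-c2ccccc2)c(C)c(C#N)c2nc(C(C)(C)C)nn12` gives 3.3. Compound 2 `CCCCc1nc2c(C#N)c(C)c(-c3ccccc3)c(N3CC[C@H](N(C)C)C3)n2n1` gives 3.2. Compound 3 `Cc1c(-c2ccccc2)c(N2CC[C@H](N(C)C)C2)n2nc(C(C)(C)CO)nc2c1C#N` gives 1.8, the lowest of the three numbers; compound 2 is its nearest neighbour and compound 1 its furthest, and both lie beyond the scatter above it. Among the measured compounds shown here, the only single-point step among the three, a number 1.40 log units lower from compound 2 to compound 3 (beyond the scatter), sets 1-(hydroxymethyl)-1-methylethyl in place of butyl on an aromatic carbon.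

Compound 4 `Cc1c(-c2ccccc2)c(N2CC[C@H](N(C)C)C2)n2nc(C(C)(C)C)nc2c1C#N` is the next member to go into this assay. It differs from compound 3 in one place: hydrogen in place of hydroxy on a saturated chain carbon, two bonds along the chain from an aromatic carbon. The step of a number 1.40 log units lower from compound 2 to compound 3 (beyond the scatter) bears on this change most directly, since that step brought the hydroxy in together with a rearranged chain. Taking the hydroxy out again is expected to undo much of that distance, although no measured pair separates the hydroxy from the branching. Compound 1, which carries tert-butyl on its core but a different amine, gives 3.3. Compound 4 is therefore expected to come out near 3.1, within a range from 2.6 to 3.6. The step of a number 1.30 log units higher from compound 3 to compound 4 (beyond the scatter) is expected to stand beyond the scatter.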

Compound 4, distribution coefficient: 3.1
Compound 4: middle estimate and measured number agree at the digits printed, and the stated range covers the measured number.
By their numbers in this assay, from the lowest: compound 3; then compounds 4, 2 and 1 (each within the scatter of the next).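

In this assay the step of a number 1.30 log units higher from compound 3 to compound 4 (beyond the scatter) shows on its own what the hydroxy on this saturated chain carbon, two bonds along the chain from an aromatic carbon, does to the number; the earlier step of a number 1.40 log units lower from compound 2 to compound 3 (beyond the scatter) had carried that hydroxy together with a rearranged chain. The step of a number 0.10 log units lower from compound 2 to compound 4 (within the scatter) sets tert-butyl in place of butyl on an aromatic carbon and stays small, so the branching without the hydroxy does not reproduce the large distance seen with 1-(hydroxymethyl)-1-methylethyl. The step of a number 0.20 log units lower from compound 1 to compound 4 (within the scatter) adds that, with tert-butyl on the core in both, 3-(dimethylamino)pyrrolidin-1-yl in place of (2-(diethylamino)ethyl)amino does not separate the two compounds in this assay and gives no sign of a change at that place.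

Nothing shown gives a reason for the size of these steps. On these data alone, it remains open whether a methoxy group, a primary amine or a carboxylic acid on this chain carbon would fall nearer compound 3 or compound 4, and whether a hydroxy on a longer, unbranched chain would give a step of similar size.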